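Working notes: aryl group variation, compounds 1 to 4

The source may report more compounds than this note shows. Statements on the series, on what has been measured and on what is new or still open speak of the compounds shown alone.

Measured so far:
compound 1, `CCC1=C(O)c2c(oc(-c3cccc(C(F)(F)F)c3)cc2=O)C(CC)(CC)C1=O`, 5.42 uM
compound 2, `CCC1=C(O)c2c(oc(-c3cccc(OC(F)(F)F)c3)cc2=O)C(CC)(CC)C1=O`, 9.95 uM
compound 3, `CCC1=C(O)c2c(oc(-c3cccc(F)c3)cc2=O)C(CC)(CC)C1=O`, 3.09 uM

In a functional assay on KBVIN cells (Homo sapiens) for antiproliferative activity, read by sulforhodamine B assay, with a stated time of 3 days (a higher number here means that more compound is needed for the effect, a lower number that less compound is needed), compound 3 gives the lowest of the three numbers; its nearest neighbour is compound 1, and that gap a 1.8-fold lower number from compound 1 to compound 3 (0.24 log units; within the scatter) is within the scatter, while the gap a 3.2-fold lower number from compound 2 to compound 3 (0.51 log units; beyond the scatter) is beyond it. Compound 4, `CCC1=C(O)c2c(oc(-c3ccc(O)c(C)c3C)cc2=O)C(CC)(CC)C1=O`, has not been measured. It differs from compound 3 by 4-hydroxy-2,3-dimethylphenyl in place of 3-fluorophenyl on an aromatic carbon.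

The measured steps all exchange one fluorine-bearing group for another on the same aryl ring: a 1.8-fold higher number from compound 1 to compound 2 (0.26 log units; within the scatter) and a 1.8-fold lower number from compound 1 to compound 3 (0.24 log units; within the scatter) stayed within the scatter, and only a 3.2-fold lower number from compound 2 to compound 3 (0.51 log units; beyond the scatter) went modestly beyond it. None of them puts a hydroxy or methyl onto that ring, so they bear on the step to compound 4 only in showing that the three aryl variants so far kept the numbers within a narrow band in this assay. Within the data shown here, with no closer precedent, the step is expected to be small: compound 4 is estimated at 5 uM, range 1.5 uM to 20 uM, which means an expected step of a 1.6-fold higher number from compound 3 to compound 4 (0.21 log units; within the scatter), with the range wide enough to allow a change in either direction.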

Compound 4, concentration for half-maximal effect: 2.75 uM
Estimate against measurement, compound 4: 1.8-fold (0.26 log units) above; the range from low to high includes it.
By their numbers in this assay, from the lowest: compounds 4, 3, 1 and 2 (each within the scatter of the next, the first and the last beyond it).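

In this assay, 4-hydroxy-2,3-dimethylphenyl in place of 3-fluorophenyl gives a 1.1-fold lower number from compound 3 to compound 4 (0.05 log units; within the scatter), so a swap of the whole aryl group leaves the number within the scatter. The earlier steps shown here only exchanged one fluorine-bearing group for another, whereas this one shows that an aryl group with no fluorine, carrying a hydroxy and two methyl groups instead, can stand at this position on the shared core with a number in the same range as compound 3. No measured property or other supporting data bear on why this step is so small.

The compounds shown do not separate the hydroxy group from the two methyl groups, as all three enter together. Going by these compounds, it also remains open whether an amine or a carboxylic acid on this aryl ring would keep the number in the same range.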